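Stereochemical pair in a half-life series

The source may report more compounds than this note shows. Statements on the series, on what has been measured and on what is new or still open speak of the compounds shown alone.

Three compounds of one series have been run in an ADME assay on the whole organism for metabolic stability, with Rattus norvegicus as the target, at a dose of 3 mg/kg by the oral route; a higher number here means that the compound lasts longer, a lower number that the compound disappears faster. Compound 1 `COC(=O)N[C@H](C(=O)N1CCC[C@H]1C(=O)Nc1ccc([C@H]2CC[C@H](c3ccc(NC(=O)[C@@H]4CCCN4C(=O)[C@@H](NC(=O)OC)C(C)C)cc3)N2c2ccc(C(F)(F)F)cc2)cc1)C(C)C` gives 4.9 h. Compound 2 `COC(=O)N[C@H](C(=O)N1CCC[C@H]1C(=O)Nc1ccc([C@H]2CC[C@H](c3ccc(NC(=O)[C@@H]4CCCN4C(=O)[C@@H](NC(=O)OC)[C@@H](C)OC)cc3)N2c2ccc(F)cc2)cc1)[C@@H](C)OC` gives 0.9 h. Compound 3 `COC(=O)N[C@H](C(=O)N1CCC[C@H]1C(=O)Nc1ccc([C@@H]2CC[C@@H](c3ccc(NC(=O)[C@@H]4CCCN4C(=O)[C@@H](NC(=O)OC)[C@H]4CCOC4)cc3)N2c2ccc(F)cc2)cc1)[C@H]1CCOC1` gives 0.6 h, the lowest of the three numbers; its nearest neighbour is compound 2, whose number is higher but within the scatter, while the gap to compound 1 lies beyond the scatter. No two of these three differ in a single place, so the gaps between them cannot be tied to one change.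

Compound 4 `COC(=O)N[C@H](C(=O)N1CCC[C@H]1C(=O)Nc1ccc([C@H]2CC[C@H](c3ccc(NC(=O)[C@@H]4CCCN4C(=O)[C@@H](NC(=O)OC)[C@H]4CCOC4)cc3)N2c2ccc(F)cc2)cc1)[C@H]1CCOC1` is the next compound for this assay. Its relation to compound 3 is the two compounds have the same atoms and bonds and differ only in configuration as drawn: 2 of 8 stereo elements differ; a stereocentre at a saturated ring carbon is drawn S in compound 3 and R in compound 4; a stereocentre at a saturated ring carbon is drawn S in compound 3 and R in compound 4. The two compounds have the same atoms and bonds and differ only in configuration as drawn: 2 of 8 stereo elements differ; a stereocentre at a saturated ring carbon is drawn S in compound 3 and R in compound 4, and a second stereocentre at a saturated ring carbon is drawn S in compound 3 and R in compound 4. The configuration drawn for compound 4 at these two centres matches that drawn for compound 1 and compound 2, though those two differ from compound 4 elsewhere as well.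

With no measured pair of this kind in hand, the step of a 1.5-fold higher number from compound 3 to compound 4 (0.18 log units; within the scatter) is expected to be small, towards a longer half-life, and quite possibly within the scatter. Compound 4 is estimated at 0.9 h, within 0.4 h to 2 h.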

Compound 4, half-life in the Rattus norvegicus assay: 0.5 h
The estimate for compound 4 lay 1.8-fold (0.26 log units) above the measured number, within the range that was stated.
By their numbers in the Rattus norvegicus assay, from the lowest: compounds 4, 3 and 2 (each within the scatter of the next); then compound 1.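

In the Rattus norvegicus assay the pair gives a 1.2-fold lower number from compound 3 to compound 4 (0.08 log units; within the scatter), so the two saturated ring carbon stereocentres, changed together, do not separate these compounds on half-life. In a physicochemical assay for solubility, in phosphate buffer, measured as kinetic solubility, at pH 7.2 (a higher number here means a more soluble compound, a lower number a less soluble compound), the same pair gives a 1.1-fold lower number from compound 3 to compound 4 (0.06 log units; within the scatter), with compound 3 at 9700 nM and compound 4 at 8500 nM, so solubility does not separate them either. This is the first comparison in the series that can be read as one change, and it is purely stereochemical: the fact that compounds 3 and 4 differ only in the configuration as drawn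

Only the change at both centres together is shown, so what each centre does alone stays open, as does whether the result holds for compound 1 and compound 2, which carry other groups. Going by these compounds, in the Rattus norvegicus assay compound 1 at 4.9 h differs from the others in more than one place, so its number cannot be tied to a single group, and it remains unknown what a nitrile in place of the fluorine of compound 3 and compound 4 would do to either read-out.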